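Working notes: methoxy in place of hydrogen, compound 3 to 4

This account rests on a few compounds, and the source may have more. Where it says the series, first, only, none or still open, it means among the compounds named here.

Measured compounds
compound 1 `CCN(CC)C(=O)c1nc2ccccc2n1Cc1ccccc1`: > 10000 nM
compound 2 `CCN(CC)C(=O)c1cc2cc(C)ccc2n1Cc1ccc(OCc2ccccc2)cc1`: > 10000 nM
compound 3 `CC(=O)N(Cc1ccccc1)c1cc(C)cc(C)c1`: 1260 nM
compound 4 `COc1ccc(CN(C(C)=O)c2cc(C)cc(C)c2)cc1`: not yet measured

In an assay on HEK293 cells for displacement of a labelled ligand from Translocator protein (Homo sapiens), read by scintillation counting, with a stated time of 90 min (a higher number here means a weaker inhibitor, a lower number a stronger inhibitor), compound 1 gives only > 10000 nM, which is a limit of the assay and not a number. Compound 2 likewise stops at > 10000 nM in this assay, again a limit. Going by the values given here, compound 3 is different: in this assay compound 3 gives 1260 nM, the only actual number in the set, while the other two entries sit at the limit of > 10000 nM in this assay, at which 2 of the 3 values shown sit. Among the compounds with values here, no pair of measured compounds differs in a single place, so no measured step is available to lean on.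

Compound 4 differs from compound 3 by methoxy in place of hydrogen on an aromatic carbon, para to a large group. Within the data shown here, with no comparable step measured, the expectation is a small change, if any, not clearly beyond the scatter, leaning slightly toward a lower value. For compound 4 in this assay the estimate is 800 nM, with a range of 250 nM to 3000 nM. This amounts to an expected step of a 1.6-fold lower number from compound 3 to compound 4 (0.20 log units; within the scatter).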

Compound 4, inhibition constant: 2790 nM
Compound 4: the middle estimate sits 3.5-fold (0.54 log units) below what was measured; the measured number falls inside the stated range.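

In this assay the series now has its first measured step in a single place: methoxy in place of hydrogen on an aromatic carbon, para to a large group, gives a 2.2-fold higher number from compound 3 to compound 4 (0.35 log units; beyond the scatter), a modest change that lies beyond the scatter. This position therefore responds to substitution, and here methoxy moves the number in the weaker direction, although compound 4 still gives an actual number and not a limit. No measured property among the data bears on the reason for this step.

A single step cannot show whether the higher number is specific to methoxy or would also follow from a fluorine, a hydroxyl or a longer alkoxy chain at this position. Compound 1 and compound 2 differ from compound 3 in more than one place, and both entries are limits, so they add nothing on this question.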